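Amide variation on the shared core: solubility notes

The source may hold more compounds than are shown below. What is called first, only, known or untested is meant among the compounds shown, and "the series" means these compounds.

Measured so far in a physicochemical assay for solubility, read by HPLC; on this read-out lower numbers stand for lower solubility and higher numbers for higher solubility:
compound 1, `CSCC(=O)N1CCN(c2nc(=O)c3cc(C(F)(F)F)cc([N+](=O)[O-])c3s2)CC1`, 15.2 ug/mL
compound 2, `Cc1ccc(C(=O)N2CCN(c3nc(=O)c4cc(C(F)(F)F)cc([N+](=O)[O-])c4s3)CC2)cc1`, 6.7 ug/mL
compound 3, `CCCCC(=O)N1CCN(c2nc(=O)c3cc(C(F)(F)F)cc([N+](=O)[O-])c3s2)CC1`, 42.5 ug/mL

Compound 1 stands second highest of the three numbers in this assay. Its nearest neighbour is compound 2, through a 2.3-fold lower number from compound 1 to compound 2 (0.36 log units; beyond the scatter), and the furthest is compound 3, through a 2.8-fold higher number from compound 1 to compound 3 (0.45 log units; beyond the scatter). Between the other two, a 6.3-fold higher number from compound 2 to compound 3 (0.80 log units; beyond the scatter).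

Compound 4, `CC(C)CC(=O)N1CCN(c2nc(=O)c3cc(C(F)(F)F)cc([N+](=O)[O-])c3s2)CC1`, is not yet measured. The change from compound 1 is isopropyl in place of methylsulfanyl on a saturated chain carbon bound to a carbonyl carbon. Going by the values given here, the step that bears on it most directly is a 2.8-fold higher number from compound 1 to compound 3 (0.45 log units; beyond the scatter), where the same position carries propyl instead of methylsulfanyl; the isopropyl of compound 4 differs from that propyl only in branching, and no measured pair here speaks to branching. The aryl case, a 2.3-fold lower number from compound 1 to compound 2 (0.36 log units; beyond the scatter), runs the other way but concerns a ring and is less relevant. The expectation is therefore a modest rise in this assay, toward the number of compound 3. The step from compound 1 is expected to be a 2.3-fold higher number from compound 1 to compound 4 (0.36 log units; beyond the scatter). Compound 4 is estimated at 35 ug/mL, with a range of 15 ug/mL to 80 ug/mL.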

Compound 4, solubility: 66.3 ug/mL
Compound 4: middle estimate off by 1.9-fold (0.28 log units), on the low side; the measured number falls inside the stated range.
By their numbers in this assay, from the lowest: compound 2; then compound 1; then compounds 3 and 4 (each within the scatter of the next).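

In this assay, isopropyl in place of methylsulfanyl on a saturated chain carbon bound to a carbonyl carbon gives a 4.4-fold higher number from compound 1 to compound 4 (0.64 log units; beyond the scatter), so compound 4 joins compound 3 as a second all-carbon group at this place that stands clear of compound 1. Branching, which no earlier pair addressed, cannot be told apart from the straight chain here: isopropyl in place of propyl gives a 1.6-fold higher number from compound 3 to compound 4 (0.19 log units; within the scatter), a step that shows no real difference. Isobutyl in place of 4-methylphenyl on a carbonyl carbon gives a 9.9-fold higher number from compound 2 to compound 4 (1.00 log units; beyond the scatter), now the widest step in the set.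

Nothing available accounts for these steps. As far as these compounds go, whether a longer chain, an amine or a carboxylic acid at this place would hold the level of compounds 3 and 4 remains open.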